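This account rests on a few compounds, and the source may have more. Where it says the series, first, only, none or still open, it means among the compounds named here.

Working notes on the series.

Compound 3 `CCOC(=O)CCCCCOc1cccc(CN(C(=O)c2ccc(-c3ccoc3)cc2)C(C)C)c1` is the point of departure here. In an ADME assay on Raji cells (Homo sapiens) for cytotoxicity, read by CellTiter-Glo and resazurin assay, with a stated time of 72 h (on this read-out higher numbers stand for an effect only at larger amounts of compound and lower numbers for an effect already at smaller amounts), compound 3 gives > 26000 nM, which is a limit of the assay and not a number. Compound 1 `CC(C)N(Cc1cccc(OCCCCCC(=O)O)c1)C(=O)c1ccc(-c2ccoc2)cc1` gives > 26000 nM in this assay, likewise a limit. Compound 2 `Cc1nnc(-c2cccc(-c3ccc(C(=O)N(Cc4cccc(OCCCCCC(=O)O)c4)C(C)C)cc3)c2)o1` gives > 26000 nM in this assay, again a limit. Compound 3 therefore stands where every value shown stands: the limit of > 26000 nM in this assay, at which 3 of the 3 values shown sit.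

The change to compound 4 `CCOC(=O)CCCCCOc1cccc(CN(C(=O)c2ccc(-c3cccc(Cl)c3)cc2)C(C)C)c1` is 3-chlorophenyl in place of furan-3-yl on an aromatic carbon. Within the data shown here, the step most closely related is the one from compound 1 to compound 2, where another aryl group takes the place of furan-3-yl on the same aromatic carbon, and that step reads a step that the two limits leave unreadable from compound 1 to compound 2. The other measured step, a step that the two limits leave unreadable from compound 1 to compound 3, touches a different part of the molecule and is equally unreadable. With no readable step in the series, no movement beyond the scatter is expected in this assay.

The step from compound 3 to compound 4 is accordingly estimated at a step that the limit leaves unreadable from compound 3 to compound 4. Compound 4 is expected to give 40000 nM in this assay, within an estimated range of 15000 nM to 110000 nM, most likely reported as a limit again.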

Compound 4, half-maximal effective concentration: > 18400 nM
Compound 4: no number, only a limit; the forecaster's own chance of this, stated with the estimate: 80%; the middle value does not contradict the limit.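

In this assay compound 4 gives > 18400 nM, a limit of the assay and not a number. Among these compounds, compound 3 gives > 26000 nM, likewise a limit, so no step between compound 3 and compound 4 can be read. The compounds shown leave open at what concentration, if any, any of them reaches a half-maximal effect on these cells.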